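From Cyclopropylmethyl to Oxan-4-yl on the Amide Nitrogen

The source may hold more compounds than are shown below. What is called first, only, known or untested is meant among the compounds shown, and "the series" means these compounds.

Going by the values given here, compound 2 `O=C(CN(CC1CC1)C(=O)c1ccc(-c2ccccn2)cc1)Nc1cc(F)cc(F)c1` gives the lowest of the two numbers so far in an in vitro ADME assay on microsomes (Rattus norvegicus) for metabolic stability (on this read-out higher numbers stand for fast clearance and lower numbers for slow clearance), at 5 mL.min-1.g-1. Among the compounds with values here, compound 1 `O=C(CN(C(=O)c1ccc(-c2ccccn2)cc1)C1CCCCC1)Nc1cc(F)cc(F)c1` gives 15.4 mL.min-1.g-1 in this assay, and the only step between measured compounds, a 3.1-fold lower number from compound 1 to compound 2 (0.49 log units; beyond the scatter), lowers the number. Compound 3 `O=C(CN(C(=O)c1ccc(-c2ccccn2)cc1)C1CCOCC1)Nc1cc(F)cc(F)c1` differs from compound 2 by oxan-4-yl in place of cyclopropylmethyl on an amide-type nitrogen. That single step bears on it only loosely, since oxan-4-yl is neither of the groups it involved, so a modest rise toward the level of compound 1 is expected, with wide uncertainty. Compound 3 is therefore estimated at 8 mL.min-1.g-1, within a range of 3.5 mL.min-1.g-1 to 18 mL.min-1.g-1. The expected step is a 1.6-fold higher number from compound 2 to compound 3 (0.20 log units; within the scatter).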

Compound 3, intrinsic clearance in microsomes: 0.6 mL.min-1.g-1
Estimate against measurement, compound 3: 13-fold (1.12 log units) above, and the stated range ends above it.
By their numbers in this assay, from the lowest: compound 3; then compound 2; then compound 1.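

In this assay the place on the amide-type nitrogen turns out to carry a far wider range than the first pair showed, with an 8.3-fold lower number from compound 2 to compound 3 (0.92 log units; beyond the scatter) and with a 26-fold lower number from compound 1 to compound 3 (1.41 log units; beyond the scatter) where oxan-4-yl replaces cyclohexyl. Oxan-4-yl enters with 6 heavy atoms against 4 for cyclopropylmethyl and the number still falls, so among these three compounds the smaller group does not give the lowest number. Nothing at hand shows what lies behind this fall.

From the compounds shown here alone, it remains open whether the ring oxygen itself matters, as a piperidin-4-yl ring carrying an amine in its place would test. An open-chain ether such as 2-methoxyethyl would show whether the ring is needed at all.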